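This account rests on a few compounds, and the source may have more. Where it says the series, first, only, none or still open, it means among the compounds named here.

Measured in an ADME assay on HEK293 cells (Homo sapiens) for cytotoxicity, read by CellTiter-Glo, with a stated time of 72 h; a higher number here means that more compound is needed for the effect, a lower number that less compound is needed:
- compound 1 `CC1=C2CC(C)(C)/C=C/[C@H](O)/C(C)=C\C3=C[C@H](C)C[C@]3(O2)C1=O`: 26000 nM
- compound 2 `CC(=O)O[C@H]1/C=C/C(C)(C)CC2=C(C)C(=O)[C@]3(C[C@@H](C)C=C3/C=C\1C)O2`: 26000 nM

On these numbers, compound 2 stands level with compound 1, and the two values lie within the scatter of each other. Compound 3 `CC1=C2CC(C)(C)/C=C/[C@H](OC(=S)Sc3ccccc3)/C(C)=C\C3=C[C@H](C)C[C@]3(O2)C1=O` has not yet been measured. Its structure differs from that of compound 2 on an oxygen on a saturated carbon: a group of 9 heavy atoms (7 carbon, 2 sulfur; one six-membered aromatic ring of carbon only) in place of a group of 3 heavy atoms (2 carbon, 1 oxygen; no ring), on an oxygen on a saturated carbon. Within the data shown here, one measured step bears on this place, no change at the digits printed from compound 1 to compound 2 (within the scatter), where acetyl took the place of hydrogen. Among the measured compounds shown here, no measured compound carries sulfur or a six-membered aromatic ring of carbon only, so the evidence is thin. In this assay, the expected step is small and has no firm direction: a 1.2-fold lower number from compound 2 to compound 3 (0.07 log units; within the scatter). For compound 3, the estimated value is 22000 nM, with an expected range from 7000 nM to 60000 nM.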

Compound 3, half-maximal effective concentration: 26000 nM
Compound 3: middle estimate off by 1.2-fold (0.07 log units), on the low side, and the stated range covers the measured number.
By their numbers in this assay, from the lowest: compounds 1, 2 and 3 (each within the scatter of the next).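

In this assay, the oxygen on a saturated carbon now carries a group of 9 heavy atoms, with sulfur and a six-membered aromatic ring of carbon only, and the read-out shows no change at the digits printed from compound 2 to compound 3 (within the scatter) for the exchange of acetyl for this group. Set against the free hydroxyl, the same group gives no change at the digits printed from compound 1 to compound 3 (within the scatter) in place of a hydrogen atom, so hydrogen, acetyl and this much bulkier group all leave the number where it was at the digits printed. Nothing measured here explains why the three values coincide.

As far as these compounds go, whether this position stays as unresponsive with an amine, a carboxylic acid or a longer alkyl chain on the same oxygen remains open. So does whether a change elsewhere on the shared core would move the number at all.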